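Shortening Propyl to Ethyl: What to Expect for Compound 3

This account rests on a few compounds, and the source may have more. Where it says the series, first, only, none or still open, it means among the compounds named here.

Two compounds share one core and differ only in the group attached to the ring amine nitrogen. Compound 1 `CC#CCn1c(N2CCC[C@@H](N)C2)nc2c1c(=O)n(CCCN1CCN(c3nc(-c4ccccc4)cs3)CC1)c(=O)n2C` carries a 4-phenyl-1,3-thiazol-2-yl group, and in a functional assay on HEK293 cells for agonist activity at Glucose-dependent insulinotropic receptor (Homo sapiens), read by a luciferase reporter (a higher number here means that more compound is needed for the effect, a lower number that less compound is needed), compound 1 gives 650 nM. Compound 2 `CC#CCn1c(N2CCC[C@@H](N)C2)nc2c1c(=O)n(CCCN1CCN(c3ncc(CCC)cn3)CC1)c(=O)n2C` carries 5-propylpyrimidin-2-yl in its place; in this assay compound 2 gives 1850 nM, the higher of the two numbers, and the step of a 2.8-fold higher number from compound 1 to compound 2 (0.45 log units; beyond the scatter) separates them. Compound 3 `CC#CCn1c(N2CCC[C@@H](N)C2)nc2c1c(=O)n(CCCN1CCN(c3ncc(CC)cn3)CC1)c(=O)n2C` differs from compound 2 by hydrogen in place of methyl on a saturated chain carbon, two bonds along the chain from an aromatic carbon, so the propyl chain becomes ethyl. Among the measured compounds shown here, no measured step bears on a change of this kind: the only step available swaps one whole ring system for another, a far larger change, and says nothing about losing a single chain carbon. With no guide of that sort, the expected step of no change at the digits printed from compound 2 to compound 3 (within the scatter) is none beyond the scatter. Compound 3 is therefore estimated at 1850 nM, within 700 nM to 4500 nM.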

Compound 3, half-maximal effective concentration: 3990 nM
Compound 3: middle estimate off by 2.2-fold (0.33 log units), on the low side; the range from low to high includes it.
By their numbers in this assay, from the lowest: compound 1; then compound 2; then compound 3.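

Losing one carbon from the chain is not a neutral change: going from propyl to ethyl gives a 2.2-fold higher number from compound 2 to compound 3 (0.33 log units; beyond the scatter) in this assay, so the length of this small chain affects how much compound is needed. Set against the thiazole group, 5-ethylpyrimidin-2-yl gives a 6.1-fold higher number from compound 1 to compound 3 (0.79 log units; beyond the scatter), a wider gap than the one 5-propylpyrimidin-2-yl showed. Nothing measured here explains why the shorter chain needs more compound.

As far as these compounds go, two chain lengths give only two points, so it remains open whether a longer chain such as butyl would lower the number, perhaps toward compound 1 at 650 nM, or whether propyl is already near the best length. Also open, from the compounds shown here alone, is how a methyl group or a cyclopropyl ring would behave on the same pyrimidine.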